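Stereocentre inversion from compound 3 to compound 4

This account rests on a few compounds, and the source may have more. Where it says the series, first, only, none or still open, it means among the compounds named here.

Measured compounds:
compound 1 `Cc1cccc(NC(=O)N[C@@H](C)c2ccccc2)c1` gives 99%
compound 2 `CCc1cccc(NC(=O)N[C@@H](C)c2ccccc2)c1` gives 100%
compound 3 `CC(=O)c1cccc(NC(=O)N[C@H](C)c2ccccc2)c1` gives 98%

In an ADME assay on the whole organism with Oryza sativa as the target, tested at 0.1 uM (a lower number here means a stronger effect, a higher number a weaker effect of the compound at the concentration tested), compound 3 gives the lowest of the three numbers, but compound 1 and compound 2 both lie within the scatter of it, so the three stand as one. Among the compounds with values here, the only measured step, a number 1 percentage points higher from compound 1 to compound 2 (within the scatter), concerns a substituent and not configuration; no measured step bears on the change to compound 4 `CC(=O)c1cccc(NC(=O)N[C@@H](C)c2ccccc2)c1`. That change: the two compounds have the same atoms and bonds and differ only in configuration as drawn: 1 of 1 stereo elements differ; a stereocentre at a saturated chain carbon is drawn R in compound 3 and S in compound 4. With nothing leaving or entering and every measured number at the top of the range, no step beyond the scatter is expected, no change at the digits printed from compound 3 to compound 4 (within the scatter). Compound 4 is therefore estimated at 98% in this assay, within 90% to 100%.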

Compound 4, a percentage reported as activity, at one concentration (the size of the read-out at that concentration, not a potency): 96%
Compound 4: middle estimate off by 2 percentage points, on the high side; the range from low to high includes it.
By their numbers in this assay, from the lowest: compounds 4, 3, 1 and 2 (each within the scatter of the next).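

In this assay inversion at the saturated chain carbon gives a number 2 percentage points lower from compound 3 to compound 4 (within the scatter), so configuration at this stereocentre produces no difference that can be told from the scatter. With the configuration of compound 4 held, the aromatic substituent does not separate the compounds either: acetyl in place of ethyl gives a number 4 percentage points lower from compound 2 to compound 4 (within the scatter), and acetyl in place of methyl gives a number 3 percentage points lower from compound 1 to compound 4 (within the scatter). The pair of compound 3 and compound 4 isolates a single change: the fact that compounds 3 and 4 differ only in the configuration as drawn

On these data alone, whether an amine or a carboxylic acid on that aromatic carbon would move the number in this assay beyond the scatter remains open, as does whether configuration would then matter.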